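Swapping the aryl amide on a shared quinoline-derived core

This account rests on a few compounds, and the source may have more. Where it says the series, first, only, none or still open, it means among the compounds named here.

Measured so far:
compound 1, `CCN1CCN(c2cc(C)c3cc(NC(=O)c4cccnc4)ccc3n2)CC1` — 10600 nM
compound 2, `CCN1CCN(c2cc(C)c3cc(NC(=O)c4ccc(F)c(F)c4)ccc3n2)CC1` — 1980 nM
compound 3, `CCN1CCN(c2cc(C)c3cc(NC(=O)c4ccc5ccccc5n4)ccc3n2)CC1` — 3760 nM

The three compounds share one core and differ only in the aryl group attached to the carbonyl of the amide. In a functional assay on SK-BR-3 cells (Homo sapiens) for antiproliferative activity, read by MTT assay, with a stated time of 72 h (on this read-out lower numbers stand for stronger inhibition and higher numbers for weaker inhibition), compound 1 gives 10600 nM, the highest number among the three. Its nearest neighbour is compound 3 at 3760 nM, and the gap is a 2.8-fold lower number from compound 1 to compound 3 (0.45 log units; beyond the scatter). The largest move is a 5.4-fold lower number from compound 1 to compound 2 (0.73 log units; beyond the scatter). Between the two lower numbers the gap is a 1.9-fold higher number from compound 2 to compound 3 (0.28 log units; within the scatter).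

Compound 4, `CCN1CCN(c2cc(C)c3cc(NC(=O)c4ccc(OC)cc4)ccc3n2)CC1`, has not yet been measured in this assay. Its change from compound 1 is 4-methoxyphenyl in place of pyridin-3-yl on a carbonyl carbon. Both earlier steps that bear on it left pyridin-3-yl for another aromatic ring and lowered the number beyond the scatter, modestly in each case. A step of similar size, downward, is therefore expected here. On that basis compound 4 is estimated at 3500 nM, with a range of 1500 nM to 9000 nM, and the expected step is a 3.0-fold lower number from compound 1 to compound 4 (0.48 log units; beyond the scatter).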

Compound 4, half-maximal inhibitory concentration: 9000 nM
Beside the measured number, compound 4's estimate is 2.6-fold (0.41 log units) below it; low and high end bracket the measured number.
By their numbers in this assay, from the lowest: compounds 2 and 3 (each within the scatter of the next); then compounds 4 and 1 (each within the scatter of the next).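

In this assay, a new aromatic ring on this carbonyl carbon does not by itself lower the number: the change to 4-methoxyphenyl gives a 1.2-fold lower number from compound 1 to compound 4 (0.07 log units; within the scatter) and so leaves the result indistinguishable from that with pyridin-3-yl. Compound 4 thus goes against the downward steps of compounds 2 and 3, and the identity of the ring matters, as shown by a 2.4-fold higher number from compound 3 to compound 4 (0.38 log units; beyond the scatter) and by a 4.5-fold higher number from compound 2 to compound 4 (0.66 log units; beyond the scatter) in the two direct comparisons. Nothing available explains these differences between the rings.

The compounds shown leave open whether 3-methoxyphenyl or 4-fluorophenyl on this carbonyl carbon would behave like 4-methoxyphenyl or like 3,4-difluorophenyl. They also leave open what a non-aromatic group such as cyclohexyl would do here.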